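A few compounds are considered here, and "the series" means these few. Any claim that something is new, unique, unknown or untested is made for them only; others in the source may bear on it.

Measured in a functional assay on HepG2 cells (Homo sapiens) for cytotoxicity, read by MTT assay, with a stated time of 48 h (a lower number here means a stronger inhibitor, a higher number a weaker inhibitor), so far:
compound 1 `Cc1ccc(-c2nnc(SCCn3c([N+](=O)[O-])cnc3C)o2)cc1` gives 2200 nM
compound 2 `Cc1ncc([N+](=O)[O-])n1CCSc1nnc(-c2ccccn2)o1` gives 20200 nM

Compound 2 holds the higher of the two numbers, which makes it the weaker inhibitor of the pair. Within the data shown here, the only measured step is a 9.2-fold higher number from compound 1 to compound 2 (0.96 log units; beyond the scatter), with pyridin-2-yl in place of 4-methylphenyl on an aromatic carbon.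

Compound 3 `Cc1ncc([N+](=O)[O-])n1CCSc1nnc(-c2ccc(N)nc2)o1` changes that same place: 6-aminopyridin-3-yl in place of pyridin-2-yl on an aromatic carbon, with 6-aminopyridin-3-yl in place of pyridin-2-yl on an aromatic carbon. Among the measured compounds shown here, no measured compound carries this group, so the evidence is thin. In this assay, for the measured compounds named here, a modest step to a lower number is expected, a weak call resting on compound 1 at 2200 nM, the one measured compound with a substituted ring. The estimated shift is a 2.2-fold lower number from compound 2 to compound 3 (0.35 log units; beyond the scatter) and no larger. Compound 3 is estimated at 9000 nM, with an expected range of 2500 nM to 30000 nM for now.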

Compound 3, half-maximal inhibitory concentration: 9400 nM
Beside the measured number, compound 3's estimate is 1.0-fold (0.02 log units) below it; low and high end bracket the measured number.
By their numbers in this assay, from the lowest: compound 1; then compound 3; then compound 2.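

In this assay, the place on the shared core that carries the aromatic ring responds to more than the swap of a 4-methylphenyl for a pyridine: a 2.1-fold lower number from compound 2 to compound 3 (0.33 log units; beyond the scatter), so the two pyridine-based groups differ from each other here. Even so, a 4.3-fold higher number from compound 1 to compound 3 (0.63 log units; beyond the scatter), which leaves compound 1, with its 4-methylphenyl, at the lowest number of the three and shows that the 6-aminopyridin-3-yl group does not close the whole gap. No data on hand give a cause for either step.

The step from compound 2 to compound 3 changes the ring's point of attachment and adds the amine together, so their shares cannot be separated. A plain pyridin-3-yl group and a 4-aminophenyl group would pull these apart, and would show whether the amine matters on a ring without a ring nitrogen.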